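Chloro to methyl: what to expect for compound 4

The source may report more compounds than this note shows. Statements on the series, on what has been measured and on what is new or still open speak of the compounds shown alone.

Three close relatives share one core and differ only in a single group on the outer ring. Compound 1 `CO/C(=C\c1ccccc1)C(=O)Nc1ccccc1` carries hydrogen there, and in a functional assay on cells (Splenocyte, Mus musculus, strain BALB/c) for inhibition, read by MTT assay, with a stated time of 48 h (a lower number here means a stronger inhibitor, a higher number a weaker inhibitor), compound 1 gives 15200 nM. Compound 2 `CO/C(=C\c1ccccc1)C(=O)Nc1ccc(F)cc1` carries fluoro instead, and in this assay compound 2 gives 4940 nM. Compound 3 `CO/C(=C\c1ccccc1)C(=O)Nc1ccc(Cl)cc1` carries chloro, and in this assay compound 3 gives 17000 nM. On these numbers compound 3 stands at the highest value of the three: its nearest neighbour is compound 1, with a 1.1-fold higher number from compound 1 to compound 3 (0.05 log units; within the scatter), a difference within the scatter, while the largest gap is the one seen as a 3.4-fold higher number from compound 2 to compound 3 (0.54 log units; beyond the scatter), beyond the scatter. The remaining measured step shows a 3.1-fold lower number from compound 1 to compound 2 (0.49 log units; beyond the scatter).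

Compound 4 `CO/C(=C\c1ccccc1)C(=O)Nc1ccc(C)cc1` is the next relative; the change from compound 3 is methyl in place of chloro on an aromatic carbon. Going by the values given here, none of the measured steps involves methyl, so the guidance is indirect. Among the compounds with values here, the one step that also exchanges a group at this place, a 3.4-fold higher number from compound 2 to compound 3 (0.54 log units; beyond the scatter), was modest, and the chloro-for-hydrogen step, a 1.1-fold higher number from compound 1 to compound 3 (0.05 log units; within the scatter), stayed within the scatter. The step of a 1.4-fold lower number from compound 3 to compound 4 (0.15 log units; within the scatter) is therefore expected to be small, within the scatter or at most a modest change in either direction. Compound 4 is estimated at 12000 nM, with a range from 4000 nM to 40000 nM.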

Compound 4, half-maximal inhibitory concentration: 16600 nM
Compound 4: middle estimate off by 1.4-fold (0.14 log units), on the low side; the measured number falls inside the stated range.
By their numbers in this assay, from the lowest: compound 2; then compounds 1, 4 and 3 (each within the scatter of the next).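

In this assay methyl and chloro cannot be told apart at this place on the outer ring: the step (a 1.0-fold lower number from compound 3 to compound 4 (0.01 log units; within the scatter)) lies within the scatter, and so does the step from hydrogen (a 1.1-fold higher number from compound 1 to compound 4 (0.04 log units; within the scatter)), which leaves hydrogen, chloro and methyl at one level. Fluoro alone stands apart, with a step beyond the scatter (a 3.4-fold higher number from compound 2 to compound 4 (0.53 log units; beyond the scatter)), so compound 2 is now the strongest inhibitor of the four, and its lead holds against a third group rather than just hydrogen and chloro. Nothing shown here accounts for why fluoro differs from the other three groups.

The compounds shown leave open whether fluoro is a lone case at this place or whether other groups, such as a methoxy group, an amine or a carboxylic acid, would also move the number beyond the scatter. Going by these compounds, whether a longer chain in place of methyl would stay at the level of hydrogen, chloro and methyl is equally open.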